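The source may report more compounds than this note shows. Statements on the series, on what has been measured and on what is new or still open speak of the compounds shown alone.

Measured compounds:
- compound 1, `COc1cc(Nc2nc(C(=N)Nc3ccc(N4CCN(C)CC4)cc3)cc3c(-c4ccccc4)n[nH]c23)cc(OC)c1OC`; in a functional assay on HT-1080 cells (Homo sapiens) for cytotoxicity, read by MTT assay, with a stated time of 72 h (a lower number here means a stronger inhibitor, a higher number a weaker inhibitor), compound 1 gives 3400 nM
- compound 2, `COc1ccc(Cn2nc(-c3ccccc3)c3cc(C(=N)Nc4ccc(N5CCN(C)CC5)cc4)nc(Nc4cc(OC)c(OC)c(OC)c4)c32)cc1`; in this assay compound 2 gives 1200 nM
- compound 3, `COc1ccc(Cn2nc(-c3ccccc3)c3cc(C(=N)Nc4ccc(N5CCN(C)CC5)cc4)nc(NC4CCCCC4)c32)cc1`; in this assay compound 3 gives 640 nM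

Compound 2 stands second highest of the three numbers in this assay. Its nearest neighbour is compound 3, with a 1.9-fold lower number from compound 2 to compound 3 (0.27 log units; within the scatter) lying within the scatter; the furthest is compound 1, with a 2.8-fold lower number from compound 1 to compound 2 (0.45 log units; beyond the scatter) lying beyond it.

Compound 4 is `COc1ccc(Cn2nc(-c3ccccc3)c3cc(C(=N)Nc4ccccc4)nc(Nc4cc(OC)c(OC)c(OC)c4)c32)cc1`. It differs from compound 2 by hydrogen in place of 4-methylpiperazin-1-yl on an aromatic carbon. Neither measured step touches this part of the molecule: the step from compound 1 to compound 2 concerns the aromatic nitrogen, the step from compound 2 to compound 3 concerns the nitrogen on the aromatic ring, and both are modest at most. Among the measured compounds shown here, no measured pair shows what removal of the 4-methylpiperazin-1-yl does, so the expectation rests only on the generally small size of the changes seen elsewhere. Compound 4 is therefore expected to sit near compound 2, with a step of a 2.1-fold higher number from compound 2 to compound 4 (0.32 log units; beyond the scatter) that is expected to stay close to the scatter, the direction being uncertain. From the compounds shown here alone, the change itself is untested, so the range is kept wide. The estimated value for compound 4 in this assay is 2500 nM, with a range from 700 nM to 9000 nM.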

Compound 4, half-maximal inhibitory concentration: 11100 nM
Estimate against measurement, compound 4: 4.4-fold (0.65 log units) below; measured number outside the range, above it.
By their numbers in this assay, from the lowest: compounds 3 and 2 (each within the scatter of the next); then compound 1; then compound 4.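

In this assay, the 4-methylpiperazin-1-yl on the aromatic carbon is where the largest single step shown so far occurs: with hydrogen in its place there is a 9.3-fold higher number from compound 2 to compound 4 (0.97 log units; beyond the scatter), against a 2.8-fold lower number from compound 1 to compound 2 (0.45 log units; beyond the scatter) at the aromatic nitrogen and a 1.9-fold lower number from compound 2 to compound 3 (0.27 log units; within the scatter) at the nitrogen on the aromatic ring. This position therefore matters more to the number than the earlier, small steps suggested, and in this one pair the presence of the 4-methylpiperazin-1-yl goes with the lower number. No measurement at hand explains why the number moves with this change.

From the compounds shown here alone, it remains open whether the step depends on the whole 4-methylpiperazin-1-yl or on only part of it, and a morpholine or a dimethylamino group on the same aromatic carbon would help to separate these readings. Going by these compounds, it is also open whether a step of this size holds with the cyclohexyl of compound 3 or the hydrogen on the aromatic nitrogen of compound 1, since the change is read here only on compound 2.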